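Chlorophenyl isomers in the series

A few compounds are considered here, and "the series" means these few. Any claim that something is new, unique, unknown or untested is made for them only; others in the source may bear on it.

Measured in a functional assay; a lower number here means a stronger inhibitor, a higher number a weaker inhibitor:
Compound 1 `CC(C)=CCOc1ccc2c(c1)OC(c1ccc(F)cc1)CC2=O`: 7320 nM
Compound 2 `CC(C)=CCOc1ccc2c(c1)OC(c1ccccc1Cl)CC2=O`: 8020 nM

Compound 2 at 8020 nM stands level with compound 1, within the scatter. Compound 3 `CC(C)=CCOc1ccc2c(c1)OC(c1cccc(Cl)c1)CC2=O` is its isomer: 3-chlorophenyl in place of 2-chlorophenyl on a saturated ring carbon, with 3-chlorophenyl in place of 2-chlorophenyl on a saturated ring carbon. Among the compounds with values here, only one measured step bears on this change, a 1.1-fold higher number from compound 1 to compound 2 (0.04 log units; within the scatter), and it stayed within the scatter. The aryl group there changed without a shift in this assay, so no step beyond the scatter is expected here. The expected step is a 1.1-fold lower number from compound 2 to compound 3 (0.03 log units; within the scatter). The estimate for compound 3 is 7500 nM, with a range of 3500 nM to 16000 nM.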

Compound 3, half-maximal inhibitory concentration: 6300 nM
Beside the measured number, compound 3's estimate is 1.2-fold (0.08 log units) above it; measured number inside the range.
By their numbers in this assay, from the lowest: compounds 3, 1 and 2 (each within the scatter of the next).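

In this assay, 3-chlorophenyl in place of 2-chlorophenyl on the saturated ring carbon gives a 1.3-fold lower number from compound 2 to compound 3 (0.10 log units; within the scatter), and 3-chlorophenyl in place of 4-fluorophenyl gives a 1.2-fold lower number from compound 1 to compound 3 (0.07 log units; within the scatter). The three aryl groups at this position therefore read alike, and moving the chlorine on the phenyl ring gives no shift beyond the scatter. No supporting data bear on this flat reading.

Open, on these data alone, is whether 4-chlorophenyl completes the same picture. Also open, as far as these compounds go, is whether this position stays as flat with an aminophenyl or a carboxylic acid-bearing phenyl group.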